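The compounds below may be only part of what the source reports. "The series", "measured", "known", "first", "only" and "open" are said of these compounds alone.

Two compounds share one core and differ only in a single group on an aromatic carbon. Compound 1 `CN1CCN(c2ccc(C3=NNC(c4ccc(N(C)C)cc4)C3)cc2)CC1` carries a 4-methylpiperazin-1-yl there, and in a functional assay on HCC1806 cells (Homo sapiens) for inhibition, read by sulforhodamine B assay, tested at 10 uM (a higher number here means more inhibition at the concentration tested (going by the name of the read-out), a lower number less inhibition), compound 1 gives 31.2%. Compound 2 `CN(C)c1ccc(C2CC(c3ccc(-n4cncn4)cc3)=NN2)cc1` carries a 1H-1,2,4-triazol-1-yl instead; in this assay compound 2 gives 6.8%, the lower of the two numbers, and the measured step is a number 24.4 percentage points lower from compound 1 to compound 2 (beyond the scatter). Compound 3 `CN(C)c1ccc(C2CC(c3ccc(-n4ccnc4)cc3)=NN2)cc1` has not yet been measured. Compared with compound 2 it changes as follows: 1H-imidazol-1-yl in place of 1H-1,2,4-triazol-1-yl on an aromatic carbon. Going by the values given here, no measured step covers this exchange of one five-membered ring for another; the only known step, a number 24.4 percentage points lower from compound 1 to compound 2 (beyond the scatter), concerns a different group and so gives no direct guide. The exchange is small, and the expected step of a number 3.2 percentage points higher from compound 2 to compound 3 (within the scatter) is accordingly none beyond the scatter. Compound 3 is estimated at 10%, with a range from 0% to 30%.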

Compound 3, a percentage reported as inhibition, at one concentration (the size of the read-out at that concentration, not a potency): -20.9%
Compound 3: the middle estimate sits 30.9 percentage points above what was measured; measured number below the stated range.
By their numbers in this assay, from the lowest: compound 3; then compound 2; then compound 1.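

At this position, even a small exchange of one five-membered aromatic ring for another matters: with the same number of heavy atoms but one ring nitrogen replaced by carbon, this assay shows a number 27.7 percentage points lower from compound 2 to compound 3 (beyond the scatter). The exchange of the 4-methylpiperazin-1-yl for the 1H-imidazol-1-yl gives a number 52.1 percentage points lower from compound 1 to compound 3 (beyond the scatter), so the three groups tested here separate beyond the scatter, with the 4-methylpiperazin-1-yl giving the highest number and the 1H-imidazol-1-yl the lowest. No measurement is available that would explain the difference between these two closely related rings. The compounds shown leave open whether a morpholin-4-yl ring or an open-chain amine at this position would match or exceed the number for compound 1. They also leave open whether the exchange of these two five-membered rings would give a similar step on a different core.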